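A few compounds are considered here, and "the series" means these few. Any claim that something is new, unique, unknown or untested is made for them only; others in the source may bear on it.

Working notes on the series. Among the measured compounds shown here, in a functional assay on microsomes from aorta for inhibition of Thromboxane-A synthase (Homo sapiens), in the presence of a further agent that is not named here (on this read-out lower numbers stand for stronger inhibition and higher numbers for weaker inhibition), compound 1 `C/C(=C/c1ccc(Cc2cccnc2)n1-c1ccccc1)C(=O)O` gives 24000 nM, the highest number among the two compounds measured so far. Compound 2 `C/C(=C/c1cc(Cc2cccnc2)n(C(C)(C)C)c1)C(=O)O`, which carries a tert-butyl group on the aromatic nitrogen and a different arrangement of substituents on the five-membered ring, gives 44 nM in this assay, a far lower number. For the measured compounds named here, no step between measured compounds that differ in a single place exists in this set, so compound 2 serves only as a pointer that an alkyl group on the aromatic nitrogen is compatible with strong inhibition.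

Compound 3 `C/C(=C/c1ccc(Cc2cccnc2)n1CC(C)(C)C)C(=O)O`, not yet measured, departs from compound 1 by neopentyl in place of phenyl on an aromatic nitrogen. Given that compound 1 gives 24000 nM and compound 2 gives 44 nM, a large step downward, well beyond the scatter, is expected in this assay. For compound 3 the expected step is a 60-fold lower number from compound 1 to compound 3 (1.78 log units; beyond the scatter). The estimated value for compound 3 is 400 nM, with a range from 40 nM to 4000 nM.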

Compound 3, half-maximal inhibitory concentration: 78000 nM
Compound 3: middle estimate off by 200-fold (2.29 log units), on the low side; the measured number lies above the stated range.
By their numbers in this assay, from the lowest: compound 2; then compound 1; then compound 3.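

In this assay, among the compounds shown here, the step of a 3.3-fold higher number from compound 1 to compound 3 (0.51 log units; beyond the scatter) is the first reading at this position in which nothing else changes, and it is modest though beyond the scatter. On the core of compound 1, replacing phenyl on the aromatic nitrogen with neopentyl, a group with no ring, does not bring the number down, so an alkyl group at this position is not enough on its own to give strong inhibition on this core. Nothing on hand accounts for the direction or size of this step.

The compounds shown leave open how a methyl, a benzyl or a tert-butyl group on the aromatic nitrogen would read on the core of compound 1. For the compounds shown here, the contribution of the arrangement of substituents on the five-membered ring also remains unresolved, as no single-place step isolates it.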